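Aminomethyl in place of methoxy: working note

The source may report more compounds than this note shows. Statements on the series, on what has been measured and on what is new or still open speak of the compounds shown alone.

In a functional assay on HCT-116 cells (Homo sapiens) for inhibition, read by MTT assay, with a stated time of 72 h (a higher number here means a weaker inhibitor of growth, a lower number a stronger inhibitor of growth), compound 1 `COc1ccc(-c2nc3c(N4CCN(Cc5cc(C)on5)CC4)c(Br)cnc3[nH]2)cc1` gives 540 nM and compound 2 `COc1ccc(-c2nc3c(N4CCN(CC5CC5)CC4)c(Br)cnc3[nH]2)cc1` gives 830 nM so the two stand level within the scatter. Compound 3 `Cc1cc(CN2CCN(c3c(Br)cnc4[nH]c(-c5ccc(CN)cc5)nc34)CC2)no1` differs from compound 1 at one place: aminomethyl in place of methoxy on an aromatic carbon on an aromatic carbon, para to a large group, taking 4-methoxyphenyl to 4-(aminomethyl)phenyl. For the measured compounds named here, the only measured step, a 1.5-fold higher number from compound 1 to compound 2 (0.19 log units; within the scatter) for cyclopropyl in place of 5-methyl-1,2-oxazol-3-yl, leaves the methoxy untouched and so gives no direct guide to this change. The estimated step is a 1.1-fold higher number from compound 1 to compound 3 (0.05 log units; within the scatter) in this assay with no shift expected beyond the scatter. For compound 3 the estimated value is 600 nM (range 200 nM to 1800 nM).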

Compound 3, concentration for 50% growth inhibition: 240 nM
Estimate against measurement, compound 3: 2.5-fold (0.40 log units) above; low and high end bracket the measured number.
By their numbers in this assay, from the lowest: compound 3; then compounds 1 and 2 (each within the scatter of the next).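

In this assay, for the compounds shown here, the change from 4-methoxyphenyl to 4-(aminomethyl)phenyl gives a 2.3-fold lower number from compound 1 to compound 3 (0.35 log units; beyond the scatter) and is the only step in this set that clears the scatter. The aromatic carbon para to a large group therefore responds to substitution, and methoxy is not needed there for growth inhibition in this assay. No measurement at hand explains the step.

On these data alone, whether a hydroxymethyl group, a carboxylic acid or a longer aminoethyl chain at this place would match aminomethyl remains open. Also open, as far as these compounds go, is whether the step carries over to the cyclopropyl side of the series.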